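The source may hold more compounds than are shown below. What is called first, only, known or untested is meant among the compounds shown, and "the series" means these compounds.

Measured compounds:
- Compound 1, `Cc1c(C(=O)NCc2cccc(C(F)(F)F)c2)cnn1-c1ccc(Cl)cc1`: in a functional assay on cells for antagonist activity at C-C chemokine receptor type 1 (Homo sapiens), read by FLIPR and calcium flux (a lower number here means a stronger inhibitor, a higher number a weaker inhibitor), compound 1 gives 600 nM.
- Compound 2, `O=C(NCc1cccc(C(F)(F)F)c1)c1cnn(-c2ccc(Cl)cc2)c1C(F)(F)F`: compound 2 gives > 3000 nM, which is a limit of the assay and not a number.
- Compound 3, `O=C(NCc1cccc(C(F)(F)F)c1)c1cnn(-c2ccc(Cl)cc2)c1CO`: compound 3 gives 1200 nM.

One of the three values sits at the limit of > 3000 nM in this assay, at which 1 of the 3 values shown sits. Compound 3 stands beside compound 1 with no separation that counts, since a 2.0-fold higher number from compound 1 to compound 3 (0.30 log units; within the scatter). The other two steps are larger: an at least 5.0-fold higher number from compound 1 to compound 2 (0.69 log units; beyond the scatter), and an at least 2.5-fold lower number from compound 2 to compound 3 (0.39 log units; beyond the scatter).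

Compound 4, `COCc1c(C(=O)NCc2cccc(C(F)(F)F)c2)cnn1-c1ccc(Cl)cc1`, differs from compound 3 by methyl in place of hydrogen on an oxygen on a saturated carbon. Going by the values given here, no measured step is of exactly this kind; the nearest bearing are the hydroxy step from compound 1 to compound 3, which stayed within the scatter, and the trifluoromethyl steps to and from compound 2, which were modest. The methoxymethyl compound is therefore expected to stay near compound 3, with a slight lean toward a higher number, so that a 1.3-fold higher number from compound 3 to compound 4 (0.10 log units; within the scatter) is expected. For compound 4 in this assay the estimate is 1500 nM, with a range from 600 nM to 4000 nM.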

Compound 4, half-maximal inhibitory concentration: > 3000 nM
Compound 4 ended at the assay's limit; the forecaster's own chance of this, stated with the estimate: 20%; at least 2.0-fold (0.30 log units) between middle value and limit.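

Methyl on the oxygen of the hydroxymethyl group matters at this position in a way the hydroxy step did not: in this assay that earlier step reads a 2.0-fold higher number from compound 1 to compound 3 (0.30 log units; within the scatter), while the new ones read an at least 2.5-fold higher number from compound 3 to compound 4 (0.39 log units; beyond the scatter) and an at least 5.0-fold higher number from compound 1 to compound 4 (0.69 log units; beyond the scatter). On these data alone, compound 4 gives > 3000 nM, which is a limit of the assay and not a number, so the true size of both new steps stays unknown. Compound 2 and compound 4 both stand at this limit, and the step between them cannot be read: the limit of > 3000 nM in this assay, at which 2 of the 4 values shown sit.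

As far as these compounds go, whether a longer chain on this oxygen, such as ethoxymethyl, would stay at the limit remains open. So does the outcome for an aminomethyl group or a carboxylic acid on the same carbon of the shared core.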